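The compounds below may be only part of what the source reports. "The series", "measured", "known", "first", "only" and "open" are said of these compounds alone.

Working notes on the series, read in a functional assay for inhibition; on this read-out lower numbers stand for stronger inhibition and higher numbers for weaker inhibition. Compound 1 `CC(C)(C)c1cc(-c2cc(=O)c3ccc(OCCCS(=O)(=O)O)cc3o2)cc(C(C)(C)C)c1O` gives 500 nM and compound 2 `CCOC(=O)CCCCOc1ccc2c(=O)cc(-c3cc(C(C)(C)C)c(O)c(C(C)(C)C)c3)oc2c1` gives 3000 nM, so compound 2 holds the higher of the two numbers, the weaker inhibition. Compound 3 `CC(C)(C)c1cc(-c2cc(=O)c3ccc(OCC(O)CO)cc3o2)cc(C(C)(C)C)c1O` differs from compound 2 by 1,2-dihydroxyethyl in place of 3-(ethoxycarbonyl)propyl on a saturated chain carbon bound to an oxygen on an aromatic ring. Going by the values given here, only one measured step bears on this, a 6.0-fold higher number from compound 1 to compound 2 (0.78 log units; beyond the scatter), where (ethoxycarbonyl)methyl replaces sulfo. Among the compounds with values here, compound 3 carries neither of those two groups, so this guide is loose, and no measured compound has the entering group. Losing the ester chain of compound 2 is expected to bring a modest move to a lower number, a 2.1-fold lower number from compound 2 to compound 3 (0.33 log units; beyond the scatter). The estimated value for compound 3 is 1400 nM, with an expected range of 400 nM to 4500 nM.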

Compound 3, half-maximal inhibitory concentration: 100 nM
Beside the measured number, compound 3's estimate is 14-fold (1.15 log units) above it; the measured number lies below the stated range.
By their numbers in this assay, from the lowest: compound 3; then compound 1; then compound 2.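

In this assay the 1,2-dihydroxyethyl group shows a 30-fold lower number from compound 2 to compound 3 (1.48 log units; beyond the scatter) and also a 5.0-fold lower number from compound 1 to compound 3 (0.70 log units; beyond the scatter) at this place, on a saturated chain carbon bound to an oxygen on an aromatic ring. Compound 3 therefore holds the lowest number of the three without any sulfo group, so a sulfo group at the chain end is not required for a lower number in this small set. The step from the ester chain shortens the chain and brings in hydroxyl groups at once, and no measurement shown accounts for the size of either step.

From the compounds shown here alone, what stays open is how much of the gain follows the hydroxyl groups and how much follows the shorter chain. A single hydroxyl on the same short chain, or a carboxylic acid or an amine at the chain end, could help separate the two.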